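From sec-butyl ester to propargyl ester: expected lipophilicity

This account rests on a few compounds, and the source may have more. Where it says the series, first, only, none or still open, it means among the compounds named here.

Compound 2 `CCC(C)OC(=O)/C=C(C)/C=C/CC(C)CCCC(C)(C)OC` is the more lipophilic of the two measured esters: in a physicochemical assay for lipophilicity (on this read-out higher numbers stand for higher lipophilicity and lower numbers for lower lipophilicity), compound 2 gives 6.49, while compound 1 `COC(=O)/C=C(C)/C=C/CC(C)CCCC(C)(C)OC` gives 5. Going by the values given here, the only measured step, a number 1.49 log units higher from compound 1 to compound 2 (beyond the scatter), shows how strongly the ester group sets this read-out. Compound 3 `C#CCOC(=O)/C=C(C)/C=C/CC(C)CCCC(C)(C)OC` differs from compound 2 by propargyl in place of sec-butyl on an oxygen next to a carbonyl group. Since propargyl carries one carbon fewer and a triple bond, a downward step is expected in this assay; compound 3 is therefore estimated at 5.7, between 5.3 and 6.2. This expectation amounts to a number 0.79 log units lower from compound 2 to compound 3 (beyond the scatter).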

Compound 3, partition coefficient: 4.66
For compound 3 the middle estimate is 1.04 log units above the measured one, and the stated range ends above it.
By their numbers in this assay, from the lowest: compound 3; then compound 1; then compound 2.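

In this assay, the change at this position gives a number 1.83 log units lower from compound 2 to compound 3 (beyond the scatter), a large drop that the earlier pair could not have revealed. The step with ethynyl in place of hydrogen on a saturated chain carbon bound to an oxygen next to a carbonyl group gives a number 0.34 log units lower from compound 1 to compound 3 (beyond the scatter), so a larger ester group here does not by itself bring a higher number. Nothing available explains this reversal. Whether the triple bond alone accounts for the drop remains open, and a propyl ester would help separate it from chain length.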